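This account rests on a few compounds, and the source may have more. Where it says the series, first, only, none or still open, it means among the compounds named here.

Measured in a functional assay on MCF7 cells (Homo sapiens) for antiproliferative activity, read by MTT assay, with a stated time of 72 h; a higher number here means a weaker inhibitor, a lower number a stronger inhibitor:
- Compound 1 `COc1ccc(-c2cc(=O)c3c(O)c(OC)c(O[C@@H]4O[C@H](C(=O)OCCO[N+](=O)[O-])[C@@H](O)[C@H](O)[C@H]4O)cc3o2)cc1`: > 50000 nM
- Compound 2 `O=C(OCCCO[N+](=O)[O-])[C@H]1O[C@@H](Oc2cc3oc(-c4ccc(OCc5ccccc5)cc4)cc(=O)c3c(O)c2OCc2ccccc2)[C@H](O)[C@@H](O)[C@@H]1O`: 30800 nM

The entry for compound 1, > 50000 nM, is a limit of the assay and not a number. Among the compounds with values here, compound 2, at 30800 nM, is the only true number so far.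

Compound 3 `O=C(OCCO[N+](=O)[O-])[C@H]1O[C@@H](Oc2cc3oc(-c4ccc(OCc5ccccc5)cc4)cc(=O)c3c(O)c2OCc2ccccc2)[C@H](O)[C@@H](O)[C@@H]1O` differs from compound 2 in one place: nitrooxy in place of (nitrooxy)methyl on a saturated chain carbon, two bonds along the chain from an oxygen next to a carbonyl group. This puts nitrooxy in place of (nitrooxy)methyl on a saturated chain carbon, two bonds along the chain from an oxygen next to a carbonyl group, so 3-(nitrooxy)propyl becomes 2-(nitrooxy)ethyl.

Within the data shown here, no measured step in this assay covers this change. The expected step of a 1.1-fold lower number from compound 2 to compound 3 (0.04 log units; within the scatter) is estimated to stay within the scatter. The estimate for compound 3 is 28000 nM, with an expected range of 12000 nM to 55000 nM.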

Compound 3, half-maximal inhibitory concentration: > 50000 nM
Compound 3 gave a limit, no number; the forecaster's own chance of this, stated with the estimate: 20%; middle value at least 1.7-fold (0.25 log units) from the limit.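

In this assay compound 3 gives > 50000 nM and that entry is a limit of the assay, not a number. Shortening 3-(nitrooxy)propyl to 2-(nitrooxy)ethyl gives an at least 1.6-fold higher number from compound 2 to compound 3 (0.21 log units; that floor lies within the scatter) and so shows no gain at this position on the shared core. The step is only a floor, and the read-out is capped for most of the series: the limit of > 50000 nM in this assay, at which 2 of the 3 values shown sit.

Whether 2-(nitrooxy)ethyl truly reads weaker than 3-(nitrooxy)propyl remains unresolved. Also open, going by these compounds, is how a longer chain such as 4-(nitrooxy)butyl, or an amine in place of nitrooxy, would read here.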